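The source may hold more compounds than are shown below. What is called first, only, known or untested is meant among the compounds shown, and "the series" means these compounds.

Measured in an ADME assay on L1210/0 cells (Mus musculus) for cytotoxicity, with a stated time of 48 h; a higher number here means a weaker inhibitor, a lower number a stronger inhibitor:
- compound 1 `Cc1ccc(-c2ncnc3c2ncn3C[C@@H]2C[C@H](CO)c3ccccc32)cc1`: 15400 nM
- compound 2 `O=C1O/C(=C\Cn2ccc(=O)[nH]c2=O)C(Cc2ccccc2)=C1O`: > 200000 nM, a limit and not a number
- compound 3 `O=c1[nH]c(=O)n([C@H]2C[C@H](O)[C@@H](CO)O2)cc1O`: > 200000 nM, a limit and not a number

Going by the values given here, compound 1 holds the only true number in this set, and the other two readings are limits. The data show (the limit of > 200000 nM in this assay, at which 2 of the 3 values shown sit).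

Next is compound 4 `OC[C@H]1C[C@@H](Cn2cnc3c(O)ncnc32)c2ccccc21`, which keeps the core of compound 1 and differs in one place: hydroxy in place of 4-methylphenyl on an aromatic carbon. This puts hydroxy in place of 4-methylphenyl on an aromatic carbon of a six-membered aromatic ring with 2 nitrogen. Among the compounds with values here, no measured pair tests this change, so the expectation rests on thin ground. Within the data shown here, compound 1, at 15400 nM, is the one compound here with the 4-methylphenyl group and the one with a number. A large step towards weaker inhibition, beyond the scatter, is expected in this assay. The expected change is a 9.7-fold higher number from compound 1 to compound 4 (0.99 log units; beyond the scatter). For compound 4 the estimated value is 150000 nM, with an expected range of 50000 nM to 200000 nM.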

Compound 4, half-maximal inhibitory concentration: > 200000 nM
Compound 4 was reported as a limit; the forecaster's own chance of this, stated with the estimate: 65%; middle value at least 1.3-fold (0.12 log units) from the limit.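

In this assay, hydroxy in place of 4-methylphenyl on this aromatic carbon gives an at least 12-fold higher number from compound 1 to compound 4 (1.11 log units; beyond the scatter). Going by these compounds, compound 4 gives > 200000 nM, which is a limit and not a number, so the true size of the step stays unknown. Going by these compounds alone, this is the first pair in the set that differs in one place, and within it the one true number goes with 4-methylphenyl on the core of compound 1, while limit readings now make up most of the set: the limit of > 200000 nM in this assay, at which 3 of the 4 values shown sit.

The compounds shown do not separate the loss of the 4-methylphenyl group from the entry of hydroxy. On these data alone, how an amine, a methoxy group or an unsubstituted phenyl on this carbon would read against compound 1 remains open.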